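Trading benzyloxy for trifluoromethoxy in compound 2

A few compounds are considered here, and "the series" means these few. Any claim that something is new, unique, unknown or untested is made for them only; others in the source may bear on it.

Measured so far in an ADME assay on MRC5 cells (Homo sapiens) for cytotoxicity; on this read-out higher numbers stand for weaker inhibition and lower numbers for stronger inhibition:
compound 1 `O=[N+]([O-])c1cn2c(n1)SCC(OCc1ccc(-c3ccc(OC(F)(F)F)cc3)cn1)C2` gives 21000 nM
compound 2 `O=[N+]([O-])c1cn2c(n1)S(=O)(=O)CC(OCc1ccc(OCc3ccccc3)cc1)C2` gives > 64000 nM
compound 3 `O=[N+]([O-])c1cn2c(n1)[S+]([O-])CC(OCc1ccc(OCc3ccccc3)cc1)C2` gives 64000 nM

Compound 2 stands at the limit of > 64000 nM in this assay, at which 1 of the 3 values shown sits, and so has no exact number of its own. Its unmeasured partner, compound 4 `O=[N+]([O-])c1cn2c(n1)S(=O)(=O)CC(OCc1ccc(OC(F)(F)F)cc1)C2`, carries trifluoromethyl in place of benzyl on an oxygen on an aromatic ring. The same difference, read one bond further out, is benzyloxy to trifluoromethoxy.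

Among the measured compounds shown here, no measured pair shows this change on its own, so the expectation rests on loose comparison. For the measured compounds named here, compound 1, the only measured compound with trifluoromethoxy, gives 21000 nM but also differs from compound 4 elsewhere. Compound 3, with benzyloxy, gives 64000 nM on the same read-out. In this assay no step beyond the scatter is expected, and any movement would more likely lean toward stronger inhibition. The estimate amounts to an expected at least 1.0-fold lower number from compound 2 to compound 4 (0.02 log units; that floor lies within the scatter) and may again end in a limit. Compound 4 is expected at 60000 nM, with an estimated range of 28000 nM to 110000 nM.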

Compound 4, half-maximal inhibitory concentration: > 64000 nM
Compound 4 was reported as a limit (the forecaster's own chance of this, stated with the estimate: 55%); middle value at least 1.0-fold (0.02 log units) from the limit.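

Among the compounds shown here, no step from compound 2 to compound 4 can be read, because both compounds are reported only as a limit, and the same one: the limit of > 64000 nM in this assay, at which 2 of the 4 values shown sit.

In this assay the compounds shown leave open whether trading benzyloxy for trifluoromethoxy shifts the read-out at all, and in which direction.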